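Replacing the Aromatic Substituent in a Small Series

The source may report more compounds than this note shows. Statements on the series, on what has been measured and on what is new or still open speak of the compounds shown alone.

Compound 1 `CC(C)(NC(=O)c1ccc([N+](=O)[O-])o1)c1ccc(Cl)cc1` gives 81000 nM in an ADME assay on Vero cells (Chlorocebus sabaeus) for cytotoxicity, read by MTT assay, with a stated time of 48 h; a higher number here means that more compound is tolerated, a lower number that less compound is tolerated. Compound 2 `COc1ccc(C(C)(C)NC(=O)c2ccc([N+](=O)[O-])o2)cc1` gives 82000 nM in this assay, and a 1.0-fold higher number from compound 1 to compound 2 (0.01 log units; within the scatter). Compound 3 `CC(C)(C)c1ccc(C(C)(C)NC(=O)c2ccc([N+](=O)[O-])o2)cc1` reaches only a limit of > 150000 nM in this assay. Compound 3 thus stands at the limit of > 150000 nM in this assay, at which 1 of the 3 values shown sits, and has no number of its own. The steps toward it were an at least 1.8-fold higher number from compound 1 to compound 3 (0.26 log units; that floor lies within the scatter) and an at least 1.8-fold higher number from compound 2 to compound 3 (0.26 log units; that floor lies within the scatter), both with floors inside the scatter. Compound 4 `CC(C)(NC(=O)c1ccc([N+](=O)[O-])o1)c1ccc(OC(F)(F)F)cc1` carries trifluoromethoxy in place of tert-butyl on an aromatic carbon. Among the compounds with values here, the only measured steps bearing on this change are the two that introduced tert-butyl on that aromatic carbon; no measured step removes it. Compound 4 is therefore expected to show an at least 1.3-fold lower number from compound 3 to compound 4 (0.13 log units; that floor lies within the scatter) in this assay, a step not clearly beyond the scatter. Compound 4 is estimated at 110000 nM, between 55000 nM and 220000 nM.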

Compound 4, half-maximal cytotoxic concentration: 70000 nM
For compound 4 the middle estimate is 1.6-fold (0.20 log units) above the measured one; measured number inside the range.
By their numbers in this assay, from the lowest: compounds 4, 1 and 2 (each within the scatter of the next). At a limit, above all of these: compound 3.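

In this assay, within the data shown here, the step of an at least 2.1-fold lower number from compound 3 to compound 4 (0.33 log units; beyond the scatter) is the first at this aromatic carbon to lie beyond the scatter, setting tert-butyl apart from trifluoromethoxy here. Against chloro and methoxy, trifluoromethoxy makes no clear difference, since a 1.2-fold lower number from compound 2 to compound 4 (0.07 log units; within the scatter) and a 1.2-fold lower number from compound 1 to compound 4 (0.06 log units; within the scatter) both stay within the scatter. The tert-butyl side of this contrast, compound 3, rests on a limit and not on a number: the limit of > 150000 nM in this assay, at which 1 of the 4 values shown sits.

As far as these compounds go, what an amine or a carboxylic acid on this aromatic carbon would give in this assay stays open, as does the true distance of compound 3 from the others.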